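Methoxy in Place of Methyl, Measured Once, Expected Again

A few compounds are considered here, and "the series" means these few. Any claim that something is new, unique, unknown or untested is made for them only; others in the source may bear on it.

Three compounds have been measured in a physicochemical assay for lipophilicity; on this read-out higher numbers stand for higher lipophilicity and lower numbers for lower lipophilicity:

Compound 1, `Cc1cccc(NC(=O)N(C)C)c1`: 1.46
Compound 2, `COc1cccc(NC(=O)N(C)C)c1`: 1.22
Compound 3, `Cc1ccc(NC(=O)N(C)C)cc1`: 1.41

Compound 2 differs from compound 1 by methoxy in place of methyl on an aromatic carbon and the step was a number 0.24 log units lower from compound 1 to compound 2 (within the scatter). Compound 3 shares its atoms with compound 1 but joins them differently; the difference between the two cores is not broken down here. In this assay compound 3 gives 1.41 and compound 1 gives 1.46, and the two values lie within the scatter of each other, as do those of compound 3 and compound 2.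

Compound 4, `COc1ccc(NC(=O)N(C)C)cc1`, has not yet been measured. It differs from compound 3 by methoxy in place of methyl on an aromatic carbon. This is the same kind of change as that from compound 1 to compound 2, though the place is not identical: in compound 2 the methoxy sits meta to a group of 6 heavy atoms, while in compound 4 it sits para to a group of 6 heavy atoms.

The expected step is a number 0.24 log units lower from compound 3 to compound 4 (within the scatter), and it is estimated at that size because the same kind of change gave a number 0.24 log units lower from compound 1 to compound 2 (within the scatter). In this assay compound 4 is therefore expected to give about 1.17, with a range from 0.9 to 1.45. This rests on one pair only, and the two places are not the same.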

Compound 4, partition coefficient: 1.02
For compound 4 the middle estimate is 0.15 log units above the measured one; the measured number falls inside the stated range.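

In this assay the replacement of methyl by methoxy on an aromatic carbon gave a number 0.39 log units lower from compound 3 to compound 4 (beyond the scatter) and so points the same way as a number 0.24 log units lower from compound 1 to compound 2 (within the scatter) on the other core, which means that both pairs shown end on the lower number. Among these compounds, only the step on the core of compound 3 lies beyond the scatter, so the two pairs support a shared direction but not a fixed size, and they cannot separate the influence of the core from that of the place, which in compound 4 is para to a group of 6 heavy atoms. Nothing at hand accounts for the result, so the reason for these steps remains unexplained.

The compounds shown leave open whether the same direction would hold on a core carrying an amine or a carboxylic acid. They also leave open what would follow if the methoxy gave way to an ethoxy or a longer chain on the same aromatic carbon, so any further carrying of this change rests on these two pairs alone.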